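From Chloro to Trifluoromethyl on the Shared Core

A few compounds are considered here, and "the series" means these few. Any claim that something is new, unique, unknown or untested is made for them only; others in the source may bear on it.

- Compound 1 (`Cc1nc(C)c(/C=C/C(=O)/C=C/c2ccc(O)cc2)nc1C`): 4790 nM
- Compound 2 (`Cc1nc(C)c(/C=C/C(=O)/C=C/c2ccc(Cl)cc2)nc1C`): 7490 nM

Both compounds were tested in a functional assay on A549/CDDP cells (Homo sapiens) for antiproliferative activity, read by MTT assay, with a stated time of 72 h; on this read-out higher numbers stand for weaker inhibition and lower numbers for stronger inhibition. Their two numbers lie within the usual scatter of each other, so compound 2 cannot be ranked against compound 1. The next structure, compound 3 (`Cc1nc(C)c(/C=C/C(=O)/C=C/c2ccc(C(F)(F)F)cc2)nc1C`), has not yet been measured. It carries trifluoromethyl in place of chloro on an aromatic carbon, para to a large group: trifluoromethyl in place of chloro on an aromatic carbon. Going by the values given here, only one measured step bears on this change: a 1.6-fold higher number from compound 1 to compound 2 (0.19 log units; within the scatter), with chloro in place of hydroxy. That step stayed within the scatter. Among the compounds with values here, a single small step is thin evidence, and no measured compound carries trifluoromethyl, so no change beyond the scatter is expected. The expected step is a 1.1-fold lower number from compound 2 to compound 3 (0.03 log units; within the scatter). Compound 3 is estimated at 7000 nM, with an expected range from 3000 nM to 16000 nM.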

Compound 3, half-maximal inhibitory concentration: 6900 nM
The estimate for compound 3 lay 1.0-fold (0.01 log units) above the measured number; low and high end bracket the measured number.
By their numbers in this assay, from the lowest: compounds 1, 3 and 2 (each within the scatter of the next).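

In this assay, trifluoromethyl in place of chloro gives a 1.1-fold lower number from compound 2 to compound 3 (0.04 log units; within the scatter), and trifluoromethyl in place of hydroxy gives a 1.4-fold higher number from compound 1 to compound 3 (0.16 log units; within the scatter). This position, on an aromatic carbon para to a large group, has now carried three different groups, and all three compounds lie within the scatter of one another, so they cannot be ranked. Even going from chloro, with 1 heavy atom, to trifluoromethyl, with 4 heavy atoms, produces no step that can be told apart from the scatter, and no separate measurement is available to explain this result.

The compounds shown leave open whether an amine, a carboxylic acid or a longer chain at this same place would move the number beyond the scatter. They also leave open whether a change elsewhere on the shared core would do so.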